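A few compounds are considered here, and "the series" means these few. Any claim that something is new, unique, unknown or untested is made for them only; others in the source may bear on it.

The measured compounds, all tested in an assay on liver (Sus scrofa) for inhibition of glucose-6-phosphatase catalytic subunit 1 (Homo sapiens), using microsomes; a lower number here means a stronger inhibitor, a higher number a weaker inhibitor:

compound 1 `Clc1ccc(/C=N/N(Cc2ccccc2)Cc2ccccc2)cc1Cl` gives 2000 nM
compound 2 `C(=N/N(Cc1ccccc1)Cc1ccccc1)\c1cccnc1` gives 3700 nM
compound 3 `CCc1ccc(/C=N/N(Cc2ccccc2)Cc2ccccc2)o1` gives 330 nM

Compound 3 gives the lowest number of the three. The steps of a 6.1-fold lower number from compound 1 to compound 3 (0.78 log units; beyond the scatter) and an 11-fold lower number from compound 2 to compound 3 (1.05 log units; beyond the scatter) both lie beyond the scatter, so compound 3 is the strongest inhibitor among the measured compounds, whereas the step of a 1.9-fold higher number from compound 1 to compound 2 (0.27 log units; within the scatter) lies within the scatter. All three share the same core and differ only in the group on the carbon with a double bond to nitrogen.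

Compound 4 `O=[N+]([O-])c1ccc(/C=N/N(Cc2ccccc2)Cc2ccccc2)o1` keeps the five-membered ring of compound 3 and alters only the group attached to it: nitro in place of ethyl on an aromatic carbon. Among the compounds with values here, none of the measured steps tests a change of this kind; each swaps the whole ring on that carbon, and no pair keeps the ring while varying a group on it. The measured steps show that this part of the molecule matters, but they give no direction for replacing ethyl by nitro. For compound 4 the expected step of a 1.2-fold higher number from compound 3 to compound 4 (0.08 log units; within the scatter) is therefore set close to no change, with a wide range to allow either direction. Compound 4 is estimated at 400 nM, with a range from 100 nM to 1600 nM in this assay.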

Compound 4, half-maximal inhibitory concentration: > 100000 nM
Compound 4: only a limit was reported; the forecaster's own chance of this, stated with the estimate: 5%; middle value at least 250-fold (2.39 log units) from the limit.
By their numbers in this assay, from the lowest: compound 3; then compounds 1 and 2 (each within the scatter of the next). At a limit, above all of these: compound 4.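

In this assay, compound 4 has a limit of the assay and not a number: the limit of > 100000 nM in this assay, at which 1 of the 4 values shown sits.

Even so, the step can be read, and an at least 300-fold higher number from compound 3 to compound 4 (2.48 log units; beyond the scatter) shows that the group on the aromatic carbon next to the ring oxygen matters greatly, even with the five-membered ring itself kept, something the earlier whole-ring swaps could not show. The two other new steps, an at least 50-fold higher number from compound 1 to compound 4 (1.69 log units; beyond the scatter) and an at least 27-fold higher number from compound 2 to compound 4 (1.43 log units; beyond the scatter), place 5-nitrofuran-2-yl behind both 3,4-dichlorophenyl and pyridin-3-yl, whereas 5-ethylfuran-2-yl stood ahead of both, so this ring type alone does not secure a low number.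

The compounds shown leave open how a methyl group, a longer chain such as propyl, an amine or a carboxylic acid would behave in that same place, so it remains unclear whether ethyl is especially favourable or nitro alone is the problem. They also cannot tell how far the true value of compound 4 lies past its limit, or what underlies this large change.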